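The source may hold more compounds than are shown below. What is called first, only, known or untested is meant among the compounds shown, and "the series" means these compounds.

Working notes on the series. In a functional assay on HCT-116 cells (Homo sapiens) for inhibition, read by MTT assay, with a stated time of 48 h (a higher number here means a weaker inhibitor, a lower number a stronger inhibitor), compound 1 `C/C=C/C(=O)N(Cc1ccc(OC)c([N+](=O)[O-])c1)c1cc(OC)c(OC)c(OC)c1` gives 670 nM and compound 2 `COc1ccc(CN(C(=O)CCCl)c2cc(OC)c(OC)c(OC)c2)cc1O` gives 150 nM. Compound 2 holds the lower of the two numbers, and its gap to compound 1 lies beyond the scatter.

Compound 3 `C/C=C/C(=O)N(Cc1ccc(OC)c(O)c1)c1cc(OC)c(OC)c(OC)c1` has not yet been measured. It differs from compound 2 in one place, with prop-1-en-1-yl in place of 2-chloroethyl on a carbonyl carbon.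

Within the data shown here, no measured pair isolates this change, so the series gives no direct size for it in this assay. Among the measured compounds shown here, the only measured compound with prop-1-en-1-yl on a carbonyl carbon is compound 1 at 670 nM, and this offers a weak hint towards a higher number. A moderate rise is therefore expected, near the edge of the scatter, with no change beyond the scatter still quite possible. The expected change is a 1.9-fold higher number from compound 2 to compound 3 (0.27 log units; within the scatter). For compound 3 the estimated value is 280 nM, with an expected range of 90 nM to 850 nM.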

Compound 3, half-maximal inhibitory concentration: 55 nM
Compound 3: middle estimate off by 5.1-fold (0.71 log units), on the high side; the whole stated range lies above it.
By their numbers in this assay, from the lowest: compound 3; then compound 2; then compound 1.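

Notes on the new reading. In this assay, among these compounds, prop-1-en-1-yl in place of 2-chloroethyl on a carbonyl carbon gives a 2.7-fold lower number from compound 2 to compound 3 (0.44 log units; beyond the scatter), so the first direct reading of this change points down, and the nitrogen-bound carbonyl position tolerates prop-1-en-1-yl without any loss. With prop-1-en-1-yl held in place, hydroxy in place of nitro on an aromatic carbon gives a 12-fold lower number from compound 1 to compound 3 (1.09 log units; beyond the scatter), a large step against the modest one above, which ties the high number of compound 1 to its nitro group rather than to prop-1-en-1-yl and leaves compound 3 lowest of the three, with its steps to both others beyond the scatter. Nothing among the data available here accounts for either step.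

The change on the carbonyl carbon swaps a chlorine-bearing chain for one with a double bond, and the compounds shown do not separate these two features; a plain propyl chain in that place would divide them. As far as these compounds go, on the aromatic carbon only hydroxy and nitro appear, so how an amine or a methoxy group would read there remains open.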